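Triazole thioethers on colon cells: amide replaces benzyl

A few compounds are considered here, and "the series" means these few. Any claim that something is new, unique, unknown or untested is made for them only; others in the source may bear on it.

Compound 3 `COc1cc(-c2nnc(SCc3ccccc3)n2-c2ccc(N(C)C)cc2)cc(OC)c1OC` is the starting point of this step. In a functional assay on HT-29 cells (Homo sapiens) for inhibition, read by MTT assay, with a stated time of 48 h (on this read-out higher numbers stand for weaker inhibition and lower numbers for stronger inhibition), compound 3 gives only a limit, > 60000 nM, not a number. Compound 1 `COc1ccc(-n2c(SCc3ccccc3)nnc2-c2cc(OC)c(OC)c(OC)c2)cc1` is its parent. In this assay compound 1 also gives only a limit, > 60000 nM. Compound 2 `CCOC(=O)CSc1nnc(-c2cc(OC)c(OC)c(OC)c2)n1-c1ccc(OC)cc1` carries ethoxycarbonyl in place of phenyl on a saturated chain carbon bound to a sulfur. In this assay compound 2 gives the same limit, > 60000 nM. All three measured values thus sit at the limit of > 60000 nM in this assay, at which 3 of the 3 values shown sit, and neither a step that the two limits leave unreadable from compound 1 to compound 2 nor a step that the two limits leave unreadable from compound 1 to compound 3 can be read as a size.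

Compound 4 `COc1ccc(NC(=O)CSc2nnc(-c3cc(OC)c(OC)c(OC)c3)n2-c2ccc(N(C)C)cc2)cc1` differs from compound 3 as follows: (4-methoxyphenyl)carbamoyl in place of phenyl on a saturated chain carbon bound to a sulfur. The change acts at the same place as the step from compound 1 to compound 2, but that step gave no readable size, so no direction can be drawn from it; the remaining step concerns the aryl substituent and does not touch this position. With every measured value at the limit, no step beyond the scatter can be predicted in this assay for this change, and the most likely outcome is again a limit. Compound 4 is therefore expected to show a step that the limit leaves unreadable from compound 3 to compound 4 relative to its parent, which in practice means no readable step. The estimate for compound 4 in this assay is 80000 nM, within 20000 nM to 300000 nM.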

Compound 4, half-maximal inhibitory concentration: 51400 nM
Beside the measured number, compound 4's estimate is 1.6-fold (0.19 log units) above it; low and high end bracket the measured number.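

In this assay, within the data shown here, compound 4 gives 51400 nM, so (4-methoxyphenyl)carbamoyl on a saturated chain carbon bound to a sulfur gives the first actual number, where phenyl and ethoxycarbonyl at this place gave none. The change reads as an at least 1.1-fold lower number from compound 3 to compound 4 (0.06 log units; that floor lies within the scatter); only this floor is known, and the true size of the step stays unreadable, since the starting value is a limit and not a number. Compound 1, compound 2 and compound 3 all remain limits, which leaves compound 4 with no second number to be compared with:
the limit of > 60000 nM in this assay, at which 3 of the 4 values shown sit.

On these data alone, it remains open whether (4-methoxyphenyl)carbamoyl also gives a number on the core of compound 1, and whether the step comes from the amide or from the methoxy group on its ring. As far as these compounds go, it is also open how a plain phenylcarbamoyl, a carboxylic acid or a longer chain between the sulfur and the carbonyl would read in this assay.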